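This account rests on a few compounds, and the source may have more. Where it says the series, first, only, none or still open, it means among the compounds named here.

Measured compounds:
compound 1, `CCCCNc1nc(N)nc2ccn(Cc3ccccc3)c12` — > 25 uM
compound 2, `CCCCNc1nc(N)nc2ccn(Cc3ccsc3)c12` — > 25 uM

In an assay on HEK293 cells for agonist activity at Toll-like receptor 8 (Homo sapiens), read by a luciferase reporter, with a stated time of 6 h (a lower number here means that less compound is needed, a higher number that more compound is needed for the effect), compound 1 gives > 25 uM, which is a limit of the assay and not a number. Compound 2 gives > 25 uM in this assay, again a limit. Compound 2 thus stands at the limit of > 25 uM in this assay, at which 2 of the 2 values shown sit, and nothing in the numbers places it above or below compound 1. For the measured compounds named here, the single step between measured compounds, a step that the two limits leave unreadable from compound 1 to compound 2, has no readable size, since both of its ends are limits.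

Compound 3, `CCCCNc1nc(N)nc2ccn(Cc3cccnc3)c12`, is not yet measured in this assay. It differs from compound 2 in one place: pyridin-3-yl in place of thiophen-3-yl on a saturated chain carbon bound to an aromatic nitrogen. Going by the values given here, the only measured step, a step that the two limits leave unreadable from compound 1 to compound 2, swaps the group at the same place but gives neither size nor direction. Among the compounds with values here, no measured step therefore bears on this change with a usable size, and no property of the entering group has been measured here. With compound 2 at the limit, the most likely outcome for compound 3 is expected to be another limit.

Compound 3 is estimated at 25 uM in this assay, within 5 uM to 60 uM. The step this implies, a number no higher from compound 2 to compound 3 (the limit leaves the size open), is expected to be small, if any.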

Compound 3, minimum effective concentration: > 25 uM
Compound 3 was reported as a limit (the forecaster's own chance of this, stated with the estimate: 65%); the middle value lies on the limit itself.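

Compound 1, compound 2 and compound 3 all stand at a limit of the assay in this assay, so no step among them can be read: the limit of > 25 uM in this assay, at which 3 of the 3 values shown sit.

Going by these compounds, whether phenyl, thiophen-3-yl and pyridin-3-yl differ at all on the saturated chain carbon bound to an aromatic nitrogen stays open, in both size and direction.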